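The source may hold more compounds than are shown below. What is called first, only, known or untested is meant among the compounds shown, and "the series" means these compounds.

Measured compounds:
Compound 1, `CCN(CC)CCN(C(=O)c1ccc(-c2ccccc2)[nH]1)C(C(=O)NC1CCCCC1)c1ccc(F)cc1`, gives 1370 nM in an assay on isolated protein for binding affinity to growth hormone secretagogue receptor type 1 (Homo sapiens); on this read-out lower numbers stand for stronger inhibition and higher numbers for weaker inhibition.
Compound 2, `CCN(CC)CCCN(C(=O)CCN1CCCc2ccccc21)C(C(=O)NC1CCCCC1)c1ccc(F)cc1`, gives 2030 nM in this assay.
Compound 3, `CCN(CC)CCCN(C(=O)c1ccc(-c2ccccc2)[nH]1)C(C(=O)NC1CCCCC1)c1ccc(O)cc1`, gives 1320 nM in this assay.

Among these three, compound 3 shows the lowest number, yet its gap to compound 1 and its gap to compound 2 both lie within the usual scatter, so nothing separates the three in this assay. The unmeasured compound 4, `CCCC(C(=O)NC1CCCCC1)N(CCCN(CC)CC)C(=O)c1ccc(-c2ccccc2)[nH]1`, differs from compound 3 in one place: propyl in place of 4-hydroxyphenyl on a saturated chain carbon bound to an amide-type nitrogen and a carbonyl carbon. Within the data shown here, no pair of measured compounds shares this kind of change, so its effect on this assay cannot be read from the data in hand. As a whole aromatic ring with its donor and acceptor is exchanged for a short chain, a step toward a higher number, somewhat beyond the scatter, is expected rather than no change, but the uncertainty is wide. The expected step is a 2.7-fold higher number from compound 3 to compound 4 (0.42 log units; beyond the scatter). Compound 4 is thus estimated at 3500 nM, within a range from 1200 nM to 10000 nM.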

Compound 4, inhibition constant: 870 nM
For compound 4 the middle estimate is 4.0-fold (0.60 log units) above the measured one, and the stated range ends above it.
By their numbers in this assay, from the lowest: compounds 4, 3, 1 and 2 (each within the scatter of the next, the first and the last beyond it).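

In this assay, placing propyl where compound 3 carries 4-hydroxyphenyl gives a 1.5-fold lower number from compound 3 to compound 4 (0.18 log units; within the scatter), so at this position the two groups cannot be told apart. This single pair shows that neither the six-membered aromatic ring nor its hydrogen-bond donor and acceptor is needed here to keep the number within the scatter of compound 3. No accompanying measurement bears on this result.

The compounds shown leave open whether a longer chain such as hexyl, or a chain ending in an amine or a carboxylic acid, would stay within the scatter at this place. They also leave open whether the exchange of 4-hydroxyphenyl for propyl gives the same result when the other parts of the molecule are changed.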